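From Trifluoromethyl to Methyl on an Aromatic Carbon

The compounds below may be only part of what the source reports. "The series", "measured", "known", "first", "only" and "open" are said of these compounds alone.

Of the compounds shown here, three built on a shared core have so far been measured in a functional assay on DLD-1 cells (Homo sapiens), read by microscopy and crystal violet staining, with a stated time of 20 h, tested at 10 ug/mL; a lower number here means less inhibition, a higher number more inhibition at the concentration tested (going by the name of the read-out). Compound 1 `O=C1NC(=S)S/C1=C\C=C\c1ccccc1OCc1ccccc1C(F)(F)F` gives 80%. Compound 2 `COc1ccccc1COc1ccccc1/C=C/C=C1\SC(=S)NC1=O` gives 98%, and compound 3 `O=C1NC(=S)S/C1=C\C=C\c1cccnc1` gives 45%. Within the data shown here, compound 1 therefore stands second highest of the three numbers: the single one-place step to compound 2 brought a number 18 percentage points higher from compound 1 to compound 2 (beyond the scatter), while the number for compound 3 lies well below that of compound 1, beyond the scatter.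

Compound 4 `Cc1ccccc1COc1ccccc1/C=C/C=C1\SC(=S)NC1=O` differs from compound 1 in one place: methyl in place of trifluoromethyl on an aromatic carbon. Among the measured compounds shown here, the only measured step that bears on this change is the exchange at the same aromatic carbon that leads from compound 1 to compound 2, where methoxy in place of trifluoromethyl gave a number 18 percentage points higher from compound 1 to compound 2 (beyond the scatter). Methyl is not methoxy, and no measured pair shows a methyl at this position, so the evidence is indirect. A rise of modest size in the same direction is nonetheless the most reasonable expectation, bounded by the ceiling of the percentage read-out.

Compound 4 is therefore expected to give 88% in this assay, with a likely range from 72% to 99%. The expected step amounts to a number 8 percentage points higher from compound 1 to compound 4 (within the scatter).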

Compound 4, a percentage reported as inhibition, at one concentration (the size of the read-out at that concentration, not a potency): 73%
Compound 4: middle estimate off by 15 percentage points, on the high side; the range from low to high includes it.
By their numbers in this assay, from the lowest: compound 3; then compounds 4 and 1 (each within the scatter of the next); then compound 2.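

In this assay, methyl in place of trifluoromethyl on this aromatic carbon, ortho to a large group, gives a number 7 percentage points lower from compound 1 to compound 4 (within the scatter) and so does not separate these two groups, a point the earlier step with methoxy could not show. The group at this carbon still matters, as methyl in place of methoxy gives a number 25 percentage points lower from compound 2 to compound 4 (beyond the scatter) and ties the clear difference at this position to methoxy, not to the removal of trifluoromethyl as such. Nothing measured here gives a property of these groups that could account for that difference.

On these data alone, it remains open whether the higher number of compound 2 depends on the oxygen of methoxy, which an ethoxy, a hydroxyl or an amine on the same carbon would help to decide. Also open, as far as these compounds go, is whether a chlorine or a nitrile here would fall with methyl and trifluoromethyl or with methoxy, and whether the same exchanges would hold on another carbon of this ring.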